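This account rests on a few compounds, and the source may have more. Where it says the series, first, only, none or still open, it means among the compounds named here.

Among the compounds with values here, in a physicochemical assay for solubility, at pH 7.4 (a higher number here means a more soluble compound, a lower number a less soluble compound), compound 1 (`Cn1cc(C(=O)Nc2ccc(-c3ccccc3)c(C(F)(F)F)c2)c(=O)c2ccccc21`) gives 1.3 ug/mL, while compound 2 (`Cn1cc(C(=O)Nc2ccc(-c3ccncc3)c(C(F)(F)F)c2)c(=O)c2ccccc21`) gives 6.4 ug/mL, the higher of the two numbers so far. Compound 3 (`Cn1cc(C(=O)Nc2ccc(-c3ccccn3)c(C(F)(F)F)c2)c(=O)c2ccccc21`) has pyridin-2-yl in place of pyridin-4-yl on an aromatic carbon, and the rest of the structure is unchanged: pyridin-2-yl in place of pyridin-4-yl on an aromatic carbon. Within the data shown here, one measured step bears on this change: a 4.9-fold higher number from compound 1 to compound 2 (0.69 log units; beyond the scatter), modest but beyond the scatter, with pyridin-4-yl replacing phenyl. Among the measured compounds shown here, no measurement yet compares pyridin-2-yl with pyridin-4-yl, so that step offers only limited guidance. Compound 3 is expected to retain part of that rise and to fall between the two measured compounds. The expected change is a 1.8-fold lower number from compound 2 to compound 3 (0.26 log units; within the scatter), a small step toward a lower number. In this assay, the estimate for compound 3 is 3.5 ug/mL, with an expected range of 1.2 ug/mL to 9.5 ug/mL.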

Compound 3, solubility: 12 ug/mL
Beside the measured number, compound 3's estimate is 3.4-fold (0.54 log units) below it; the measured number lies above the stated range.
By their numbers in this assay, from the lowest: compound 1; then compounds 2 and 3 (each within the scatter of the next).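

In this assay pyridin-2-yl in place of phenyl gives a 9.2-fold higher number from compound 1 to compound 3 (0.97 log units; beyond the scatter) and pyridin-4-yl gives a 4.9-fold higher number from compound 1 to compound 2 (0.69 log units; beyond the scatter) so at this place, on an aromatic carbon ortho to a trifluoromethyl group, the rise over phenyl is not confined to a single pyridine isomer. Exchanging pyridin-4-yl for pyridin-2-yl amounts to a 1.9-fold higher number from compound 2 to compound 3 (0.27 log units; within the scatter) and so does not separate these two groups: among the compounds shown, which pyridine isomer is present cannot be told from this read-out. Nothing available explains the rise with either group.

As far as these compounds go, it remains open whether pyridin-3-yl, a pyrimidine ring or a phenyl ring carrying an amine at this place would give a similar number. Also open, from the compounds shown here alone, is whether the rise over phenyl would persist if a nitrile replaced the trifluoromethyl group.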